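Swapping an Ether for a Ketone on the Side Chain

A few compounds are considered here, and "the series" means these few. Any claim that something is new, unique, unknown or untested is made for them only; others in the source may bear on it.

Three compounds share one core and differ only in the group at the end of a short chain on an aromatic nitrogen. Compound 1 `CCCn1c(=O)n(C)c(=O)c2c1ncn2CCC#N` carries a cyano group there and gives 88600 nM in an assay on Cerebral cortex for binding affinity to adenosine receptor A1 (Cavia porcellus), read by radioligand binding; a lower number here means a stronger inhibitor, a higher number a weaker inhibitor. Compound 2 `CCCn1c(=O)n(C)c(=O)c2c1ncn2CCN(C)C` carries a dimethylamino group. For compound 2 this assay reports only a limit, > 200000 nM (the limit of > 200000 nM in this assay, at which 1 of the 3 values shown sits). Compound 3 `CCCn1c(=O)n(C)c(=O)c2c1ncn2CCOCC` carries an ethoxy group and gives 24300 nM, the lowest of the two numbers shown; its nearest neighbour is compound 1, with a 3.6-fold lower number from compound 1 to compound 3 (0.56 log units; beyond the scatter).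

Compound 4 `CCCn1c(=O)n(C)c(=O)c2c1ncn2CC(C)=O` is compound 3 with acetyl in place of ethoxymethyl on a saturated chain carbon bound to an aromatic nitrogen. The measured steps all concern the same end of the chain: a 3.6-fold lower number from compound 1 to compound 3 (0.56 log units; beyond the scatter), an at least 8.2-fold lower number from compound 2 to compound 3 (0.91 log units; beyond the scatter) and an at least 2.2-fold higher number from compound 1 to compound 2 (0.35 log units; beyond the scatter). Every exchange at that position moved the number beyond the scatter, so a change here is expected to matter. The acetyl group brings a carbonyl as acceptor, as the cyano group of compound 1 did, and that compound gave 88600 nM. For compound 4 a modestly higher number than compound 3 is therefore expected, with a 1.9-fold higher number from compound 3 to compound 4 (0.27 log units; within the scatter), and an estimated value of 45000 nM, likely between 15000 nM and 150000 nM.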

Compound 4, inhibition constant: 95700 nM
The estimate for compound 4 lay 2.1-fold (0.33 log units) below the measured number; the range from low to high includes it.
By their numbers in this assay, from the lowest: compound 3; then compounds 1 and 4 (each within the scatter of the next). At a limit, above all of these: compound 2.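

In this assay, replacing ethoxymethyl with acetyl gives a 3.9-fold higher number from compound 3 to compound 4 (0.60 log units; beyond the scatter), so a second end group with a single hydrogen-bond acceptor and no net charge does not match the number of compound 3. Among these compounds, until now every exchange at this position had moved the number beyond the scatter, but acetyl and cyanomethyl give the first pair of end groups that cannot be told apart, with a 1.1-fold higher number from compound 1 to compound 4 (0.03 log units; within the scatter). Compound 2 is known here only as a limit, so acetyl gives an at least 2.0-fold lower number from compound 2 to compound 4 (0.32 log units; beyond the scatter), a step whose true size stays unknown: the limit of > 200000 nM in this assay, at which 1 of the 4 values shown sits.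

The exchange from 2-ethoxyethyl to 2-oxopropyl alters the oxygen and the length of the side chain together, and the compounds shown cannot separate these two parts of the change. Also open, going by these compounds, is whether a longer ether chain, a hydroxyl or a carboxylic acid at the end of the chain would bring the number lower than that of compound 3, which so far gives the lowest number in the set.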